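This account rests on a few compounds, and the source may have more. Where it says the series, first, only, none or still open, it means among the compounds named here.

In a physicochemical assay for lipophilicity (on this read-out higher numbers stand for higher lipophilicity and lower numbers for lower lipophilicity), compound 2 (`CC(C)(c1cc([C@@]23CCOC[C@@H]2C3)nc(-c2ccc(NC(=S)NCCO)cc2)n1)S(C)(=O)=O`) gives 3.9, level with compound 3 (`CCNC(=O)Nc1ccc(-c2nccc([C@@]34CCOC[C@@H]3C4)n2)cc1`) at 3.9. Compound 1 (`CNCC(=O)Nc1ccc(-c2nc(CS(C)(=O)=O)cc([C@@]34CCOC[C@@H]3C4)n2)cc1`) gives 3.1, lower than both and beyond the scatter. Compound 4 (`CNCC(=O)Nc1ccc(-c2nc(C(C)(C)S(C)(=O)=O)cc([C@@]34CCOC[C@@H]3C4)n2)cc1`) replaces one group of compound 2, on a nitrogen on an aromatic ring, with ((methylamino)methyl)carbonyl: a group of 5 heavy atoms (3 carbon, 1 nitrogen, 1 oxygen; no ring) in place of a group of 6 heavy atoms (3 carbon, 1 nitrogen, 1 oxygen, 1 sulfur; no ring), on a nitrogen on an aromatic ring. Going by the values given here, no measured pair isolates this change. A downward step in this assay is expected because compound 1, which carries the same entering group, gives 3.1. Compound 1 also differs from compound 4 elsewhere, so only part of that gap is expected to carry over. The expected step is a number 0.40 log units lower from compound 2 to compound 4 (beyond the scatter), modest but beyond the scatter. For compound 4 the estimated value is 3.5, with an expected range of 3 to 4.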

Compound 4, partition coefficient: 4.3
For compound 4 the middle estimate is 0.80 log units below the measured one; measured number above the stated range.
By their numbers in this assay, from the lowest: compound 1; then compounds 2 and 3 (each within the scatter of the next); then compound 4.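

In this assay, 1-methyl-1-(methylsulfonyl)ethyl in place of (methylsulfonyl)methyl on an aromatic carbon gives a number 1.20 log units higher from compound 1 to compound 4 (beyond the scatter) as the first single-place read of that change. With ((methylamino)methyl)carbonyl entering on a nitrogen on an aromatic ring, the series shows a number 0.40 log units higher from compound 2 to compound 4 (beyond the scatter) and so the low number of compound 1 does not travel with that group. No available measurement accounts for either step. Open, from the compounds shown here alone, is whether a dimethylamino group in place of the methylamino end of the entering group keeps the number of compound 4. Also open, going by these compounds, is how an ethyl sulfone in place of the methylsulfonyl end reads on the same core.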